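The source may hold more compounds than are shown below. What is called first, only, known or untested is meant among the compounds shown, and "the series" means these compounds.

Measured so far:
Compound 1, `O=c1c(-c2nn[nH]n2)c[nH]c2c(Br)cccc12`: in a functional assay on the whole organism (strain Sprague-Dawley) for inhibition, with Rattus norvegicus as the target (a lower number here means that less compound is needed, a higher number that more compound is needed for the effect), compound 1 gives > 10 mg/kg.
Compound 2, `CS(=O)(=O)c1cccc2c(=O)c(-c3nn[nH]n3)c[nH]c12`: in this assay compound 2 gives > 25 mg/kg.

Neither of these is a number; each is a limit of this assay. Compound 1 sits at the limit of > 10 mg/kg in this assay, at which 1 of the 2 values shown sits. Compound 2 sits at the limit of > 25 mg/kg in this assay, at which 1 of the 2 values shown sits. Going by the values given here, the one measured step, a step that the two limits leave unreadable from compound 1 to compound 2, therefore has no readable size and no readable direction. Where compound 2 stands is known only as this limit, and the other value shown is a limit as well.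

The new compound, compound 3, `COc1cccc2c(=O)c(-c3nn[nH]n3)c[nH]c12`, differs from compound 2 in one place: methoxy in place of methylsulfonyl on an aromatic carbon. Among the compounds with values here, no measured step bears on this change, and the single step that exists is unreadable, so the data give no ground to expect a step in this assay in either direction beyond the usual scatter. The most that can be said is that compound 3 is expected to stand near the limit at which compound 2 sits.

In this assay compound 3 is estimated at 30 mg/kg, with a range from 8 mg/kg to 100 mg/kg. The step this estimate means, a step that the limit leaves unreadable from compound 2 to compound 3, is an expected one and not a measured one.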

Compound 3, minimum effective dose: 0.312 mg/kg
Beside the measured number, compound 3's estimate is 96-fold (1.98 log units) above it, outside the stated range (below it).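

Going by these compounds alone, compound 3 is the one compound here that gives a real number rather than a limit in this assay, and it shows that the group on this aromatic carbon can matter a great deal: methoxy in place of methylsulfonyl gives an at least 80-fold lower number from compound 2 to compound 3 (1.90 log units; beyond the scatter), and methoxy in place of bromo gives an at least 32-fold lower number from compound 1 to compound 3 (1.50 log units; beyond the scatter). These sizes are minimums, and compound 1 on its side of the step is known only as a limit: the limit of > 10 mg/kg in this assay, at which 1 of the 3 values shown sits. Compound 2 is likewise known only as a limit: the limit of > 25 mg/kg in this assay, at which 1 of the 3 values shown sits.

The step between compound 1 and compound 2 still cannot be read, and the compounds shown do not explain why methoxy stands so far from the other two groups. From the compounds shown here alone, whether this result is special to methoxy or extends to other groups on this carbon stays open, and a hydroxy group, a longer ethoxy chain or an amine in the same place would begin to answer that.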